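The compounds below may be only part of what the source reports. "The series", "measured", "known", "first", "only" and "open" are said of these compounds alone.

Measured so far in a functional assay on SK-MEL-28 cells (Homo sapiens) for antiproliferative activity; a higher number here means a weaker inhibitor, a lower number a stronger inhibitor:
Compound 1 `O=C(CCCCC[C@H](NC(=O)c1ccc(Br)cc1)C(=O)Nc1ccc(-c2ccccc2)cc1)NO`: 168 nM
Compound 2 `O=C(/C=C/c1ccccc1)N[C@@H](CCCCCC(=O)NO)C(=O)Nc1cccc2cccnc12`: 37 nM

Of these two, compound 2 has the lower number, 37 nM, and so is the stronger inhibitor. The gap to compound 1 at 168 nM lies beyond the usual scatter. However, these two compounds differ in more than one place, so their gap cannot be tied to any single change.

The next structure is compound 3 `CC(C)COC(=O)N[C@@H](CCCCCC(=O)NO)C(=O)Nc1cccc2cccnc12`, which has isobutoxy in place of 2-phenylethenyl on a carbonyl carbon. Among the measured compounds shown here, no measured pair shows this change alone, so any expectation in this assay is a judgement. The expected change is a 1.9-fold higher number from compound 2 to compound 3 (0.28 log units; within the scatter), a small move towards a higher number that may stay within the scatter. For compound 3 the estimated value is 70 nM, with an expected range from 22 nM to 220 nM.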

Compound 3, half-maximal inhibitory concentration: 170 nM
Compound 3: the middle estimate sits 2.4-fold (0.39 log units) below what was measured; the range from low to high includes it.
By their numbers in this assay, from the lowest: compound 2; then compounds 1 and 3 (each within the scatter of the next).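

Among the compounds shown here, this is the first step here that can be read as a single change: in this assay, isobutoxy in place of 2-phenylethenyl on a carbonyl carbon gives a 4.6-fold higher number from compound 2 to compound 3 (0.66 log units; beyond the scatter) for the pair. This position is therefore not indifferent to the group it carries: 2-phenylethenyl, with its six-membered aromatic ring and double bond, belongs to the stronger inhibitor of the pair, and isobutoxy, with no ring, belongs to the weaker one. Nothing measured here accounts for this gap.

As far as these compounds go, it remains open whether the ring, the double bond or the overall size of the group matters most. A plain phenyl or a benzyloxy group on the same carbonyl carbon would help separate these features.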